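One Added Methyl on the Carboxymethyl Chain

The compounds below may be only part of what the source reports. "The series", "measured", "known", "first", "only" and "open" are said of these compounds alone.

Compound 1, `O=C(CN(c1nc(Cl)nc2[nH]cnc12)C1CC1)NCC(=O)OCc1ccccc1`: 27.2%
Compound 2, `O=C(CN(c1ncnc2c1ncn2C1CCCCO1)C1CC1)NCC(=O)OCc1ccccc1`: 25.9%
Compound 3, `O=C(O)CNC(=O)CN(c1nc(Cl)nc2[nH]cnc12)C1CC1`: 32.3%

Of the compounds shown here, three have been measured in a functional assay on the whole organism (Tail, strain ICR) with Mus musculus as the target, in the tail flick test, with a stated time of 90 min, at a dose of 25 umol/kg by the oral route; on this read-out lower numbers stand for a weaker effect and higher numbers for a stronger effect at the one dose given. Compound 3 gives 32.3%, and its differences to compound 1 and to compound 2 both lie within the usual scatter, so the three numbers cannot be told apart. Among the measured compounds shown here, the one directly comparable step, a number 5.1 percentage points higher from compound 1 to compound 3 (within the scatter), is likewise within the scatter. Compound 4, `C[C@H](NC(=O)CN(c1nc(Cl)nc2[nH]cnc12)C1CC1)C(=O)O`, is not yet measured; it differs from compound 3 by methyl in place of hydrogen on a saturated chain carbon bound to an amide-type nitrogen and a carbonyl carbon. For the measured compounds named here, no measured pair shows this change, so the only guide is that every number so far sits close together. Compound 4 is therefore expected to stay near compound 3, with a step of a number 2.3 percentage points lower from compound 3 to compound 4 (within the scatter) that is not beyond the scatter. The estimated value of compound 4 is 30%, ranging from 18% to 42%.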

Compound 4, a percentage reported as activity, at one dose (the size of the read-out at that dose, not a potency): 43.5%
For compound 4 the middle estimate is 13.5 percentage points below the measured one, and the stated range ends below it.
By their numbers in this assay, from the lowest: compounds 2, 1 and 3 (each within the scatter of the next); then compound 4.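

In this assay, among the compounds shown here, methyl in place of hydrogen on a saturated chain carbon bound to an amide-type nitrogen and a carbonyl carbon gives a number 11.2 percentage points higher from compound 3 to compound 4 (beyond the scatter) and is the first step here to clear the scatter. This chain carbon is therefore a place where one added carbon can change the read-out, while the step from benzyl to hydrogen on the oxygen stayed within the scatter. Nothing measured here explains the gain. On these data alone, whether an ethyl group or a longer chain on this carbon would raise the number further stays open. So does whether the same methyl would matter with a benzyl ester in place of the carboxylic acid.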